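The source may hold more compounds than are shown below. What is called first, only, known or untested is meant among the compounds shown, and "the series" means these compounds.

Measured so far in a functional assay (Oryctolagus cuniculus) for inhibition of platelet-activating factor receptor (Cavia porcellus); a higher number here means a weaker inhibitor, a lower number a stronger inhibitor:
compound 1, `CCCCCCCCCCCCCCOCC1COC(COCCCCCC[n+]2ccsc2)C1`, gives 1400 nM
compound 2, `CCCCCCCCCCCCCCOCC1COC(COCCCCCCC[n+]2ccsc2)C1`, gives 1700 nM

Compound 2 has only compound 1 beside it, and the step of a 1.2-fold higher number from compound 1 to compound 2 (0.08 log units; within the scatter) lies within the scatter, so the two numbers cannot be told apart. That step changes a ring group on one chain and says nothing about the other. The unmeasured compound 3, `CCCCCCCCCCCCOCC1COC(COCCCCCCC[n+]2ccsc2)C1`, differs from compound 2 in a different place: hydrogen in place of ethyl on a saturated chain carbon, ten or more bonds along the chain from an oxygen on a saturated carbon. Going by the values given here, none of the measured steps touches this part of the molecule, so no measured step bears on the change. With nothing in the data pointing either way, no step beyond the scatter is expected, and the estimated step is no change at the digits printed from compound 2 to compound 3 (within the scatter). Compound 3 is therefore estimated at 1700 nM, with a range from 600 nM to 5000 nM.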

Compound 3, half-maximal inhibitory concentration: 1100 nM
The estimate for compound 3 lay 1.5-fold (0.19 log units) above the measured number; low and high end bracket the measured number.
By their numbers in this assay, from the lowest: compounds 3, 1 and 2 (each within the scatter of the next).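

In this assay, hydrogen in place of ethyl on a saturated chain carbon, ten or more bonds along the chain from an oxygen on a saturated carbon, gives a 1.5-fold lower number from compound 2 to compound 3 (0.19 log units; within the scatter). Going by these compounds alone, this is the first measured step in this part of the molecule, and it shows that compound 2 and compound 3 cannot be told apart in this assay, even though the ethyl group is gone. No measurement here bears on why the numbers stay this close.

On these data alone, whether a longer chain, or an amine or a carboxylic acid at this place, would give a step beyond the scatter remains open. Also open, as far as these compounds go, is whether the same change would read alike on compound 1.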